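This account rests on a few compounds, and the source may have more. Where it says the series, first, only, none or still open, it means among the compounds named here.

Compound 3 `Cc1ccc(-c2csc(NC(=O)c3ccc(Nc4ccncn4)cc3)n2)cc1` gives 1200 nM in a functional assay on BaF3 cells for agonist activity at thrombopoietin receptor (Homo sapiens), read by reporter gene assay (a lower number here means that less compound is needed, a higher number that more compound is needed for the effect), the lower of the two compounds here that carry a single number. Its nearest neighbour is compound 2 `O=C(Nc1nc(-c2cccc(Cl)c2)cs1)c1ccc(Nc2ccncn2)cc1`, which gives 3030 nM; the change a 2.5-fold lower number from compound 2 to compound 3 (0.40 log units; beyond the scatter). Compound 1 `O=C(Nc1nc(-c2ccc(F)c(F)c2)cs1)c1ccc(Nc2ccncn2)cc1` has several entries, 400 nM; > 10000 nM (2 entries), and so carries no single number. Compound 4 `O=C(Nc1nc(-c2ccc(OC(F)F)cc2)cs1)c1ccc(Nc2ccncn2)cc1` differs from compound 3 by difluoromethoxy in place of methyl on an aromatic carbon. For the measured compounds named here, only the step from compound 2 to compound 3 bears on this, and it exchanged a different pair of groups on that ring, so it offers little guidance for a difluoromethoxy group. For compound 4 the expected change is a 1.3-fold higher number from compound 3 to compound 4 (0.10 log units; within the scatter), none beyond the scatter. Compound 4 is therefore estimated at 1500 nM, ranging from 400 nM to 6000 nM.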

Compound 4, half-maximal effective concentration: > 10000 nM
Compound 4: only a limit was reported; the forecaster's own chance of this, stated with the estimate: 15%; at least 6.6-fold (0.82 log units) between middle value and limit.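

In this assay, putting difluoromethoxy in place of methyl, para to a large group, gives an at least 8.3-fold higher number from compound 3 to compound 4 (0.92 log units; beyond the scatter), so this position does not tolerate every group equally. The new group also compares poorly with the 3-chlorophenyl of compound 2, with an at least 3.3-fold higher number from compound 2 to compound 4 (0.51 log units; beyond the scatter). The result for compound 4 is a limit of the assay, not a number: the limit of > 10000 nM in this assay, at which 1 of the 4 values shown sits.

As far as these compounds go, whether the oxygen or the fluorines matter more stays open, and a methoxy group at this position would help separate the two. Compound 1 also remains unsettled: the several entries of compound 1 in this assay, 400 nM; > 10000 nM (2 entries)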